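A few compounds are considered here, and "the series" means these few. Any claim that something is new, unique, unknown or untested is made for them only; others in the source may bear on it.

Compound 1 `C=C1C[C@]23C[C@@]1(O)CC[C@H]2c1ccc(OS(=O)(=O)c2ccc(C)cc2)c(C)c1[C@@H]3Cn1cc(-c2ccc(Br)cc2)nn1`, compound 2 `C=C1C[C@]23C[C@@]1(O)CC[C@H]2c1ccc(OS(=O)(=O)c2ccc(C)cc2)c(C)c1[C@@H]3Cn1cc(-c2ccc(OC)cc2)nn1` and compound 3 `C=C1C(=O)[C@]23C[C@@]1(O)CC[C@H]2c1ccc(O)c(C)c1[C@@H]3Cn1cc(-c2ccc(OC)cc2)nn1` have been measured in a functional assay on MCF7 cells (Homo sapiens) for cytotoxicity, read by MTT assay, with a stated time of 4 days; a higher number here means a weaker inhibitor, a lower number a stronger inhibitor. In this assay compound 1 gives > 20000 nM, which is a limit of the assay and not a number. Compound 2 gives > 20000 nM, likewise a limit. Within the data shown here, compound 3 gives 1710 nM, the only number among the three. The change from compound 2 to compound 1 is bromo in place of methoxy on an aromatic carbon; its step that the two limits leave unreadable from compound 2 to compound 1 cannot be read because the limit of > 20000 nM in this assay, at which 2 of the 3 values shown sit, holds both values. The difference between the core of compound 3 and the core of compound 2 is not broken down here. Compound 4 `C=C1C(=O)[C@]23C[C@@]1(O)CC[C@H]2c1ccc(O)c(C)c1[C@@H]3Cn1cc(-c2ccc(Br)cc2)nn1` is not yet measured; it differs from compound 3 by bromo in place of methoxy on an aromatic carbon, the same change at the same place. Among the measured compounds shown here, with the one measured instance of this change unreadable, the expected step is a 1.2-fold higher number from compound 3 to compound 4 (0.07 log units; within the scatter), a small one. Compound 4 is estimated at 2000 nM, between 700 nM and 6000 nM.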

Compound 4, half-maximal inhibitory concentration: 270 nM
Beside the measured number, compound 4's estimate is 7.4-fold (0.87 log units) above it; the measured number lies below the stated range.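

On the core of compound 3, bromo in place of methoxy gives a 6.3-fold lower number from compound 3 to compound 4 (0.80 log units; beyond the scatter) in this assay, so on this core the 4-bromophenyl compound is the stronger inhibitor. The same change on the core of compound 2 cannot be read, because compound 2 and compound 1 both sit at one limit, which is not a number: the limit of > 20000 nM in this assay, at which 2 of the 4 values shown sit. This leaves a single readable instance on a single core, which shows neither that the gain carries over to another core nor that it fails to.

Going by these compounds, it remains open whether another group at this place, such as chloro, an amine or a carboxylic acid, would go the same way as bromo. Also open, on these data alone, is which part of the difference between the core of compound 3 and the core of compound 2 matters in this assay.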